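From 4-methylphenyl to 4-nitrophenyl in the growth series

The source may hold more compounds than are shown below. What is called first, only, known or untested is meant among the compounds shown, and "the series" means these compounds.

In a functional assay on MCF7 cells (Homo sapiens) for inhibition, read by sulforhodamine B assay, with a stated time of 48 h (on this read-out lower numbers stand for stronger inhibition of growth and higher numbers for weaker inhibition of growth), compound 3 (`Cc1ccc(-c2c(CNC(C)(C)C)c(C(=O)O)nn2-c2ccccc2)cc1`) gives > 688000 nM, which is a limit of the assay and not a number. Compound 2 (`CC(C)(C)NCc1c(C(=O)O)nn(-c2ccccc2)c1-c1ccccc1`) gives > 716000 nM, also only a limit. For the measured compounds named here, the only measured step on this position is a step that the two limits leave unreadable from compound 2 to compound 3, so it gives no size to carry forward. Going by the values given here, compound 1 (`CCOC(=O)c1nn(-c2ccccc2)c(-c2ccc([N+](=O)[O-])cc2)c1CNC(C)(C)C`) also carries the 4-nitrophenyl and gives 206000 nM; 169000 nM (2 entries), the only real numbers so far.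

The next change leads to compound 4 (`CC(C)(C)NCc1c(C(=O)O)nn(-c2ccccc2)c1-c1ccc([N+](=O)[O-])cc1`), with nitro in place of methyl on an aromatic carbon, 4-methylphenyl to 4-nitrophenyl: nitro in place of methyl on an aromatic carbon. Among the compounds with values here, compound 1 at 206000 nM; 169000 nM (2 entries) leaves some room for expecting a modest move towards stronger inhibition, but no measured step supports a firm size. Another limit is the likeliest report. The expected change is small: an at least 1.1-fold lower number from compound 3 to compound 4 (0.05 log units; that floor lies within the scatter). For compound 4 the estimated value is 600000 nM, with an expected range of 250000 nM to 950000 nM.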

Compound 4, concentration for 50% growth inhibition: > 634000 nM
Compound 4: a limit, no number; the forecaster's own chance of this, stated with the estimate: 65%; at least 1.0-fold (0.02 log units) between middle value and limit.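

In this assay compound 4 gives > 634000 nM, a limit and not a number. For the compounds shown here, with compound 2, compound 3 and compound 4 all standing as limits, no step among them can be read. The compounds shown leave open what size, if any, the change from 4-methylphenyl to 4-nitrophenyl has on growth inhibition.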